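Cyclohexyl to butoxy on a weakly active compound

This account rests on a few compounds, and the source may have more. Where it says the series, first, only, none or still open, it means among the compounds named here.

Compound 1 `COc1cc(/C=C/C(=O)c2ccc(C3CCCCC3)cc2)cc(OC)c1`: 39000 nM
Compound 2 `COc1cc(/C=C/C(=O)c2ccc(O)cc2O)ccc1O`: 31000 nM

Going by the values given here, only two compounds have been measured so far, both in a functional assay (Homo sapiens) for inhibition; a lower number here means a stronger inhibitor, a higher number a weaker inhibitor. There, compound 1 gives 39000 nM and compound 2 gives 31000 nM. These two numbers lie within the usual scatter of repeated measurements, so they cannot be ranked against each other. Compound 1 therefore has a close neighbour but no clear position above or below it.

The next compound, compound 3 `CCCCOc1ccc(C(=O)/C=C/c2cc(OC)cc(OC)c2)cc1`, keeps the core of compound 1 and changes one group. It carries butoxy in place of cyclohexyl on an aromatic carbon, para to a large group (butoxy in place of cyclohexyl on an aromatic carbon).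

Among the compounds with values here, no two measured compounds differ in just one place, so nothing here shows directly what a single change of this kind does. The expectation is thus no step beyond the scatter, with a wide margin of doubt, starting from compound 1 at 39000 nM. The expected change is a 1.3-fold lower number from compound 1 to compound 3 (0.11 log units; within the scatter). The estimate for compound 3 is 30000 nM, with an expected range of 10000 nM to 90000 nM.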

Compound 3, half-maximal inhibitory concentration: 52000 nM
Compound 3: middle estimate off by 1.7-fold (0.24 log units), on the low side; the range from low to high includes it.
By their numbers in this assay, from the lowest: compounds 2, 1 and 3 (each within the scatter of the next).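

Going by these compounds alone, this is the first pair of compounds that differ in just one place, and in this assay replacing cyclohexyl with butoxy gives a 1.3-fold higher number from compound 1 to compound 3 (0.12 log units; within the scatter) and so leaves the two compounds indistinguishable. On this aromatic carbon, para to a large group, a six-membered ring of carbon only can therefore give way to an open chain carrying one oxygen and one hydrogen-bond acceptor without any step beyond the usual scatter, at least on the core of compound 1. No separate measurement speaks to the reason for this result.

Within the data shown here, this single pair tests only two groups at one position, so it remains open whether any other group placed there, such as an amine, a carboxylic acid or a longer chain, would move the number beyond the scatter. Going by these compounds, it also remains open whether the same replacement would give a similar result on a different core, since one step on a weakly active compound cannot show how general the outcome is.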